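Working notes: methyl placement on the hydroxyphenyl group

The compounds below may be only part of what the source reports. "The series", "measured", "known", "first", "only" and "open" are said of these compounds alone.

- compound 1 `Cc1ncc([N+](=O)[O-])n1CCSc1nnc(-c2ccccc2)o1` gives 17500 nM in a functional assay on HepG2 cells (Homo sapiens) for cytotoxicity, read by MTT assay, with a stated time of 48 h; a lower number here means a stronger inhibitor, a higher number a weaker inhibitor
- compound 2 `Cc1cccc(-c2nnc(SCCn3c([N+](=O)[O-])cnc3C)o2)c1O` gives 8700 nM in this assay

On these numbers, compound 2 cannot be separated from compound 1. Going by the values given here, the only measured step is a 2.0-fold lower number from compound 1 to compound 2 (0.30 log units; within the scatter) and it lies within the scatter.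

Compound 3 `Cc1ccc(-c2nnc(SCCn3c([N+](=O)[O-])cnc3C)o2)c(O)c1` differs from compound 2 as follows: 2-hydroxy-4-methylphenyl in place of 2-hydroxy-3-methylphenyl on an aromatic carbon with the same atoms joined differently. In words, 2-hydroxy-4-methylphenyl stands in place of 2-hydroxy-3-methylphenyl on an aromatic carbon.

Among the compounds with values here, no measured step covers this exact change. Within the data shown here, the one step available, from phenyl to 2-hydroxy-3-methylphenyl, is a different replacement and stays within the scatter. No step beyond the scatter is therefore expected in this assay and no direction can be assigned. The expected step is a 1.0-fold higher number from compound 2 to compound 3 (0.01 log units; within the scatter) and it is estimated to stay within the scatter. Compound 3 is expected at 9000 nM with 4000 nM to 20000 nM as the estimated range.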

Compound 3, half-maximal inhibitory concentration: 16600 nM
For compound 3 the middle estimate is 1.8-fold (0.27 log units) below the measured one, within the range that was stated.
By their numbers in this assay, from the lowest: compounds 2, 3 and 1 (each within the scatter of the next).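

Working notes, continued: with 2-hydroxy-4-methylphenyl in place of 2-hydroxy-3-methylphenyl, the series shows a 1.9-fold higher number from compound 2 to compound 3 (0.28 log units; within the scatter) and the two methyl placements cannot be told apart on these numbers. Against the phenyl group of compound 1, the new group shows a 1.1-fold lower number from compound 1 to compound 3 (0.02 log units; within the scatter) and so also stays inseparable from the unsubstituted ring. Both hydroxymethylphenyl groups therefore now lie within the scatter of phenyl, and neither methyl placement gives a measurable separation at this position on the five-membered aromatic ring. No supporting data bear on these results.

Open, going by these compounds, is whether any group on this phenyl ring can produce a step beyond the scatter, for example an amine or a carboxylic acid in place of the hydroxy group. The separate contributions of the hydroxy and methyl groups also remain unresolved.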